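The source may hold more compounds than are shown below. What is called first, only, known or untested is meant among the compounds shown, and "the series" means these compounds.

Working notes on the series. In an ADME assay on MDCK cells (Canis lupus familiaris) for cytotoxicity (a lower number here means that less compound is tolerated, a higher number that more compound is tolerated), compound 2 (`O=[N+]([O-])C1=NNc2nc(C(F)(F)F)nn2C1c1ccc(O)cc1O`) gives 108000 nM. Compound 1 (`CSc1nc2n(n1)C(O)C([N+](=O)[O-])=NN2`) gives 99000 nM and compound 3 (`O=[N+]([O-])C1=NNc2ncnn2C1c1ccc(O)cc1O`) gives 90000 nM. The three values lie within the scatter of one another, so compound 2 does not stand apart from the other two.

The open compound is compound 4 (`O=[N+]([O-])C1=NNc2nc(C(F)(F)F)nn2C1O`), which differs from compound 2 as follows: hydroxy in place of 2,4-dihydroxyphenyl on a saturated ring carbon. This puts hydroxy in place of 2,4-dihydroxyphenyl on a saturated ring carbon.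

For the measured compounds named here, the only measured step, a 1.2-fold lower number from compound 2 to compound 3 (0.08 log units; within the scatter), concerns an aromatic carbon and leaves 2,4-dihydroxyphenyl in place, so it bears on this change only indirectly. Going by the values given here, no measured step isolates the change itself. The nearest evidence is compound 1, which already carries hydroxy on that saturated ring carbon and gives 99000 nM, although it has methylthio rather than trifluoromethyl on the aromatic carbon.

Among the compounds with values here, with so few compounds the support is thin, but nothing measured so far points to a move beyond the scatter in this assay. The expected change is a 1.1-fold lower number from compound 2 to compound 4 (0.03 log units; within the scatter), which would be no real step in either direction. For compound 4 the estimated value is 100000 nM, with an expected range of 55000 nM to 180000 nM.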

Compound 4, half-maximal cytotoxic concentration: 40000 nM
Compound 4: middle estimate off by 2.5-fold (0.40 log units), on the high side; the whole stated range lies above it.
By their numbers in this assay, from the lowest: compound 4; then compounds 3, 1 and 2 (each within the scatter of the next).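

In this assay, for the compounds shown here, the saturated ring carbon proves not to be a neutral position when trifluoromethyl sits on the aromatic carbon: the change from 2,4-dihydroxyphenyl to hydroxy gives a 2.7-fold lower number from compound 2 to compound 4 (0.43 log units; beyond the scatter), the first step to lie beyond the scatter. The aromatic carbon also responds once hydroxy occupies the saturated ring carbon, since trifluoromethyl in place of methylsulfanyl gives a 2.5-fold lower number from compound 1 to compound 4 (0.39 log units; beyond the scatter). Going by these compounds alone, with 2,4-dihydroxyphenyl in place, the only earlier step at the aromatic carbon, a different replacement, stayed within the scatter at a 1.2-fold lower number from compound 2 to compound 3 (0.08 log units; within the scatter), so the two positions may not act independently, although the differing replacements and the modest sizes of both new steps keep this tentative.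

The compounds shown leave open whether an amine or a methoxy group on the saturated ring carbon would give a number like that of compound 4 or like that of compound 2, and whether the lower number needs hydroxy specifically rather than merely the loss of 2,4-dihydroxyphenyl. Nothing available accounts for either new step.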